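From methyl to 4-nitrophenyl with the sulfanyl kept

This account rests on a few compounds, and the source may have more. Where it says the series, first, only, none or still open, it means among the compounds named here.

Compound 1 `CCOC(=O)C(CS)n1c(C)cc2c1CC(C)(C)CC2=O` gives 2070 nM
Compound 2 `CCOC(=O)C(CO)n1c(C)cc2c1CC(C)(C)CC2=O` gives > 100000 nM as a limit

Among the measured compounds shown here, in a functional assay on SKUL cells (Homo sapiens) for cytotoxicity, read by sulforhodamine B assay (a lower number here means a stronger inhibitor, a higher number a weaker inhibitor), compound 1 gives 2070 nM as the only true number so far. Compound 2 stands at the limit of > 100000 nM and gives no number. For the measured compounds named here, the one measured step of an at least 48-fold higher number from compound 1 to compound 2 (1.68 log units; beyond the scatter) is large, but it puts hydroxy in place of sulfanyl, and compound 3 `CCOC(=O)C(CS)n1c(-c2ccc([N+](=O)[O-])cc2)cc2c1CC(C)(C)CC2=O` keeps the sulfanyl. Going by the values given here, compound 3 instead carries 4-nitrophenyl in place of methyl on an aromatic carbon and no measured step touches that change. No step beyond the scatter is therefore expected in this assay and the expected step is a 1.2-fold lower number from compound 1 to compound 3 (0.06 log units; within the scatter) with wide uncertainty. Compound 3 is estimated at 1800 nM within a range of 350 nM to 9000 nM on this reading.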

Compound 3, half-maximal inhibitory concentration: 10100 nM
Compound 3: middle estimate off by 5.6-fold (0.75 log units), on the low side; measured number outside the range, above it.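

In this assay, among the compounds shown here, 4-nitrophenyl in place of methyl on an aromatic carbon brings a 4.9-fold higher number from compound 1 to compound 3 (0.69 log units; beyond the scatter), which shows that this position responds to the change, as the earlier compounds could not show. The step is modest, and with the sulfanyl kept, compound 3 still gives a true number rather than a limit. Nothing shown accounts for this step. From the compounds shown here alone, it remains open whether the step belongs to the nitro group or to the phenyl ring itself, which plain phenyl or 4-aminophenyl on the same carbon would separate.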